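The source may report more compounds than this note shows. Statements on the series, on what has been measured and on what is new or still open speak of the compounds shown alone.

Measured so far in an in vitro ADME assay on microsomes from liver (Homo sapiens) for metabolic stability, read by LC-MS; a higher number here means that the compound lasts longer, a lower number that the compound disappears faster:

Compound 1 `C=CCON/C(=N\C1=NC(=O)C(=O)N1C(C)C)Nc1ccc(Cl)c(Cl)c1`: > 1 h
Compound 2 `CC(C)N1C(=O)C(=O)N=C1/N=C(\NOCc1ccccc1)Nc1ccc(Cl)c(Cl)c1`: 0.215 h
Compound 3 `CN/C(=N\C1=NC(=O)C(=O)N1C(C)C)Nc1ccc(Cl)c(Cl)c1`: > 1 h

Compound 3 stands at > 1 h, which is a limit of the assay and not a number. Its exact half-life is therefore unknown.

Compound 4 `CC(C)N/C(=N\C1=NC(=O)C(=O)N1C(C)C)Nc1ccc(Cl)c(Cl)c1` differs from compound 3 by one change, isopropyl in place of methyl on an amine nitrogen. Among the compounds with values here, no measured step makes this exact swap, but two change the group on that same nitrogen. Methyl in place of benzyloxy gave an at least 4.6-fold higher number from compound 2 to compound 3 (0.66 log units; beyond the scatter), so this group can matter in this assay. Methyl in place of allyloxy gave a step that the two limits leave unreadable from compound 1 to compound 3, so that pair sets no size. Phenyl in place of vinyl gave an at least 4.6-fold lower number from compound 1 to compound 2 (0.66 log units; beyond the scatter), which points the same way as the benzyloxy result.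

Only compound 2 has dropped off the limit, so a small fall or no change beyond the scatter is expected. The expected change is an at least 1.1-fold lower number from compound 3 to compound 4 (0.04 log units; that floor lies within the scatter). For compound 4 the estimated half-life is 0.9 h, with an expected range of 0.35 h to 2 h.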

Compound 4, half-life: > 1 h
Compound 4: a limit, no number; the forecaster's own chance of this, stated with the estimate: 50%; middle value at least 1.1-fold (0.04 log units) from the limit.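

In this assay compound 4 gives > 1 h, which is a limit of the assay and not a number. Isopropyl on this amine nitrogen therefore joins methyl and allyloxy at the limit, while benzyloxy remains the only group shown that falls off it, and replacing benzyloxy with isopropyl gives an at least 4.6-fold higher number from compound 2 to compound 4 (0.66 log units; beyond the scatter). The steps to compound 4 from compound 1 and from compound 3 cannot be read, because all three compounds sit at the same limit: the limit of > 1 h in this assay, at which 3 of the 4 values shown sit.

As far as these compounds go, the true half-lives of these three compounds remain unknown, so methyl, isopropyl and allyloxy cannot be ranked against one another. From the compounds shown here alone, it also remains open whether a longer chain such as n-butyl, or a cyclohexyl ring, on this nitrogen would stay at the limit or drop below it as compound 2 does.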